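The source may hold more compounds than are shown below. What is called first, only, known or untested is meant among the compounds shown, and "the series" means these compounds.

Measured compounds in a functional assay on HCT-116 cells (Homo sapiens) for antiproliferative activity, read by MTT assay, with a stated time of 72 h; on this read-out higher numbers stand for weaker inhibition and lower numbers for stronger inhibition:
Compound 1 `COc1ccc(-c2cn(C/C=C3\OC(=O)C(OCc4ccccc4)=C3OCc3ccccc3)nn2)cc1` gives > 100000 nM, which is a limit of the assay rather than a number.
Compound 2 `CCCCCCCCCCc1cn(C[C@H](O)[C@H]2OC(=O)C(OCc3ccccc3)=C2OCc2ccccc2)nn1` gives 28800 nM.
Compound 3 `O=C1O/C(=C\Cn2cc(-c3cccc(O)c3)nn2)C(OCc2ccccc2)=C1OCc1ccccc1` gives 63600 nM.

Of the two numbers, compound 2 has the lowest, with compound 3 next; the remaining value is the limit (the limit of > 100000 nM in this assay, at which 1 of the 3 values shown sits). Compound 4 `O=C1O[C@H]([C@@H](O)Cn2ccnn2)C(OCc2ccccc2)=C1OCc1ccccc1` has not yet been measured. It differs from compound 2 by hydrogen in place of decyl on an aromatic carbon. Among the compounds with values here, the only measured step, an at least 1.5-fold lower number from compound 1 to compound 3 (0.19 log units; that floor lies within the scatter), concerns 3-hydroxyphenyl in place of 4-methoxyphenyl, a different change, so no measured step bears directly on the removal of the decyl group. Compound 4 is nevertheless expected to give a higher number in this assay, a step of a 2.8-fold higher number from compound 2 to compound 4 (0.44 log units; beyond the scatter), with a real chance that only a limit is reported. The estimate for compound 4 is 80000 nM, in a range from 30000 nM to 200000 nM.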

Compound 4, half-maximal inhibitory concentration: > 100000 nM
Compound 4: no number, only a limit (the forecaster's own chance of this, stated with the estimate: 35%); middle value at least 1.2-fold (0.09 log units) away from the limit.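

In this assay, hydrogen in place of decyl on the aromatic carbon gives an at least 3.4-fold higher number from compound 2 to compound 4 (0.54 log units; beyond the scatter). This shows that the group at this carbon of the five-membered aromatic ring matters for the read-out, which the earlier step between two aryl groups, lying within the scatter at its floor, could not show. The value of compound 4 is a limit, so this step is only a floor: the limit of > 100000 nM in this assay, at which 2 of the 4 values shown sit.

From the compounds shown here alone, whether a shorter chain, or a chain ending in an amine, would hold the number of compound 2 remains open. So does whether decyl would act the same way on the core of compound 1.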